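Halogenated aryl variants on a shared core: one isomer step

The source may hold more compounds than are shown below. What is called first, only, known or untested is meant among the compounds shown, and "the series" means these compounds.

Measured compounds:
- compound 1 `COc1cc2c(Nc3ccc(Cl)cc3F)ncnc2c(OC)c1OC`, > 30000 nM
- compound 2 `COc1cc2c(Nc3ccc(C(F)(F)F)cc3)ncnc2c(OC)c1OC`, > 30000 nM
- compound 3 `COc1cc2c(Nc3cccc(C(F)(F)F)c3)ncnc2c(OC)c1OC`, > 30000 nM

In a functional assay on SGC-7901 cells (Homo sapiens) for antiproliferative activity, read by MTT assay, with a stated time of 72 h (on this read-out higher numbers stand for weaker inhibition and lower numbers for stronger inhibition), compound 1 gives only a limit, > 30000 nM. Compound 2 likewise sits at a limit, > 30000 nM. Compound 3 also gives a limit, > 30000 nM. So compound 1 stands nowhere in particular on the numbers shown: all three values are the same limit, (the limit of > 30000 nM in this assay, at which 3 of the 3 values shown sit), and no ordering among compounds 1, 2 and 3 can be read from them.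

Compound 4 `COc1cc2c(Nc3ccc(F)c(Cl)c3)ncnc2c(OC)c1OC` differs from compound 1 by 3-chloro-4-fluorophenyl in place of 4-chloro-2-fluorophenyl on a nitrogen on an aromatic ring. Among the compounds with values here, with every measured value at the limit, there is no measured step on which to size this change. The expectation is that compound 4 stays near the limit as well, with a step from compound 1 to compound 4 of a number no higher from compound 1 to compound 4 (the limit leaves the size open) expected to be none beyond the scatter. Compound 4 is therefore estimated at 30000 nM in this assay, within 10000 nM to 90000 nM.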

Compound 4, half-maximal inhibitory concentration: 5420 nM
Compound 4: the middle estimate sits 5.5-fold (0.74 log units) above what was measured; measured number below the stated range.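

Within the data shown here, compound 4 is the only compound here that gives a number rather than a limit in this assay, so the arrangement of the same atoms in the aryl group on this nitrogen on an aromatic ring can alone move the read-out. The exchange of 4-chloro-2-fluorophenyl for 3-chloro-4-fluorophenyl gives an at least 5.5-fold lower number from compound 1 to compound 4 (0.74 log units; beyond the scatter). That step is only a minimum, and no other step can be read: the limit of > 30000 nM in this assay, at which 3 of the 4 values shown sit.

Among these compounds, the single step does not separate the part played by the chlorine from that of the fluorine. On these data alone, how an aryl group carrying an amine or a carboxylic acid would read in this assay remains open.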